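Microsomal clearance notes on one aryl substituent swap

This account rests on a few compounds, and the source may have more. Where it says the series, first, only, none or still open, it means among the compounds named here.

Measured so far:
compound 1 `Cc1cc(C)c(CN2CCc3c(Cl)cc([C@@H](C)CO)c(Cl)c3C2=O)c(=O)[nH]1`: 12.4 uL/min
compound 2 `Cc1cc(C)c(CN2CCc3c(Cl)cc(-c4c(C)noc4C)c(Cl)c3C2=O)c(=O)[nH]1`: 107 uL/min
compound 3 `COC(C)c1cc(Cl)c2c(c1Cl)C(=O)N(Cc1c(C)cc(C)[nH]c1=O)CC2`: 190 uL/min; 158 uL/min (2 entries)

In an ADME assay on microsomes from liver (Homo sapiens) for metabolic stability, read by LC-MS, using NADPH, with stated times of 10 min and 45 min, tested at 1 uM (a lower number here means slower removal, a higher number faster removal of the compound), compound 2 gives 107 uL/min, the higher of the two single numbers; compound 1 is the nearest, and compound 3 appears only as the repeated entries (the several entries of compound 3 in this assay, 190 uL/min; 158 uL/min (2 entries)). Within the data shown here, the one step measured in one place is an 8.6-fold higher number from compound 1 to compound 2 (0.94 log units; beyond the scatter), where 3,5-dimethyl-1,2-oxazol-4-yl replaced 1-(hydroxymethyl)ethyl.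

Compound 4 `Cc1cc(C)c(CN2CCc3c(Cl)cc([C@@H](CO)[C@H]4CCCO4)c(Cl)c3C2=O)c(=O)[nH]1` reverses that direction: a group of 8 heavy atoms (6 carbon, 2 oxygen; one five-membered non-aromatic ring with 1 hetero atom) in place of a group of 7 heavy atoms (5 carbon, 1 nitrogen, 1 oxygen; one five-membered aromatic ring with 2 hetero atoms), on an aromatic carbon. The entering group again counts 1 hydrogen-bond donor, as compound 1 does with 1-(hydroxymethyl)ethyl, so a step back toward the value of compound 1 is expected rather than a shift within the scatter. The expected step is a 3.1-fold lower number from compound 2 to compound 4 (0.49 log units; beyond the scatter). Compound 4 is therefore estimated at 35 uL/min, between 12 uL/min and 100 uL/min.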

Compound 4, intrinsic clearance in a liver preparation (reported as CLH), per the amount of preparation that the assay uses in the liver assay: 43 uL/min
The estimate for compound 4 lay 1.2-fold (0.09 log units) below the measured number; the range from low to high includes it.
By their numbers in the liver assay, from the lowest: compound 1; then compound 4; then compound 2.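

In the liver assay, the group with the five-membered non-aromatic ring places compound 4 apart from both earlier single-number compounds at this aromatic carbon: a 2.5-fold lower number from compound 2 to compound 4 (0.40 log units; beyond the scatter), and a 3.5-fold higher number from compound 1 to compound 4 (0.54 log units; beyond the scatter). The position therefore gives an intermediate number, not only the two earlier ones. In a physicochemical assay for solubility, measured as kinetic solubility (on this read-out higher numbers stand for higher solubility and lower numbers for lower solubility), compound 2 gives 93000 nM and compound 4 gives 576000 nM, the higher of the two, beyond the scatter.

Still open, as far as these compounds go, is whether the ring alone accounts for the rise from compound 1 to compound 4. Also open, from the compounds shown here alone, is how an amine or a carboxylic acid at this carbon would read in either assay.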